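A few compounds are considered here, and "the series" means these few. Any claim that something is new, unique, unknown or untested is made for them only; others in the source may bear on it.

Three closely related compounds built on the same core were tested for their ability to slow the growth of colon cancer cells. Compound 1 `C=C1CC[C@@H]2CCC3=C(C2(C)C)[C@@](OC)(C/C(C)=C/[C@@H](O)C1)OC3=O` is one of them. In a functional assay on WiDr cells (Homo sapiens) for cytotoxicity, read by MTT assay (a lower number here means a stronger inhibitor, a higher number a weaker inhibitor), compound 1 gives > 20 ug/mL, which is a limit of the assay rather than a measured number. Compound 2 `C=C1CC[C@@H]2CCC3=C(C(=O)[C@@H](/C(C)=C/C(O)C1)[C@H]3O)C2(C)C` gives > 20 ug/mL in this assay, again a limit. Compound 3 `C=C1CC[C@@H]2CCC3=C(C(=O)[C@@H](/C(C)=C/[C@@H](OC(C)=O)C1)[C@H]3O)C2(C)C` gives > 20 ug/mL in this assay, also a limit. Compound 1 therefore stands where every value here stands: at the limit of > 20 ug/mL in this assay, at which 3 of the 3 values shown sit. Within the data shown here, no two measured compounds differ in just one place, so no single measured step can be set out.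

Compound 4 `C=C1CC[C@@H]2CCC3=C(C2(C)C)[C@@](O)(C/C(C)=C/[C@@H](O)C1)OC3=O` differs from compound 1 by hydrogen in place of methyl on an oxygen on a saturated carbon; cut one bond further out, the change reads methoxy to hydroxy.

With every measured value sitting at the limit, the step from compound 1 to compound 4 is expected to be a step that the limit leaves unreadable from compound 1 to compound 4, none beyond the scatter in either direction. Compound 4 is expected to give 30 ug/mL, somewhere between 15 ug/mL and 80 ug/mL, most likely reported again as a limit.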

Compound 4, half-maximal inhibitory concentration: > 20 ug/mL
Compound 4: a limit, no number; the forecaster's own chance of this, stated with the estimate: 80%; the middle value does not contradict the limit.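

No size can be read for the change from methoxy to hydroxy between compound 1 and compound 4, because both stop at the same limit: the limit of > 20 ug/mL in this assay, at which 4 of the 4 values shown sit.

The compounds shown leave open whether any change to the shared core gives a true number in this assay rather than a limit.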